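The source may report more compounds than this note shows. Statements on the series, on what has been measured and on what is new or still open speak of the compounds shown alone.

Measured in a functional assay on SMMC-7721 cells (Homo sapiens) for cytotoxicity, read by MTT assay, with a stated time of 48 h; on this read-out higher numbers stand for weaker inhibition and lower numbers for stronger inhibition:
compound 1, `C=CC(=C)CC[C@@H]1[C@@]2(C)CCC[C@](C)(COC(=O)/C=C/c3ccc(O)cc3)[C@@H]2CC[C@@]1(C)O`: 15500 nM
compound 2, `C=C[C@@]1(C)O[C@H]1C[C@H]1C(=C)CC[C@@H]2[C@]1(C)CCC[C@]2(C)C(=O)O`: > 40000 nM

Compound 1 gives a number in this assay. For compound 2 this assay returns only a limit, > 40000 nM, and no number; this is the limit of > 40000 nM in this assay, at which 1 of the 2 values shown sits, so where compound 2 stands on the scale is known only as a lower bound, and no ordering against compound 1 is set beyond that. Among the measured compounds shown here, no step between measured compounds is available here.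

Compound 3, `C=C[C@]1(C)O[C@H]1C[C@H]1C(=C)CC[C@@H]2[C@]1(C)CCC[C@]2(C)C(=O)O`, is the next member. Against compound 2 the change is the two compounds have the same atoms and bonds and differ only in configuration as drawn: 1 of 6 stereo elements differ; a stereocentre at a saturated ring carbon is drawn R in compound 2 and S in compound 3. With compound 2 at a limit, there is nothing to anchor a directional prediction, and an inversion of a single stereocentre on the shared core is expected to move the read-out by a step of a number no higher from compound 2 to compound 3 (the limit leaves the size open) of no size beyond the scatter. Compound 3 is thus expected to sit at about 40000 nM, with a range from 15000 nM to 80000 nM, and most likely again to be reported only as a limit.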

Compound 3, half-maximal inhibitory concentration: > 40000 nM
Compound 3: only a limit was reported; the forecaster's own chance of this, stated with the estimate: 70%; the middle value lies on the limit itself.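

Compound 2 and compound 3 are both reported only as limits in this assay, and no step can be read between them. Left open is whether the configuration at the saturated ring carbon, R in compound 2 and S in compound 3, affects the read-out at all.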